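A Methyl Group Enters the Arylpiperazine of Compound 2

A few compounds are considered here, and "the series" means these few. Any claim that something is new, unique, unknown or untested is made for them only; others in the source may bear on it.

Among the compounds with values here, compound 2 `O=c1cc(-c2ccc(Cl)cc2)oc2cc(OCCCCN3CCN(c4ccccc4)CC3)ccc12` is one of two compounds measured in a functional assay for antagonist activity at Adrenergic receptor alpha-1 (Rattus norvegicus); on this read-out lower numbers stand for tighter binding and higher numbers for weaker binding; compound 2 gives 12.2 nM, the higher of the two numbers. Within the data shown here, compound 1 `O=c1cc(-c2ccccc2)oc2cc(OCCCCN3CCN(c4ccccc4)CC3)ccc12` gives 4.65 nM in this assay, and the only measured step, a 2.6-fold higher number from compound 1 to compound 2 (0.42 log units; beyond the scatter), is chloro in place of hydrogen on an aromatic carbon. Compound 3 `Cc1ccccc1N1CCN(CCCCOc2ccc3c(=O)cc(-c4ccc(Cl)cc4)oc3c2)CC1` is not yet measured. It differs from compound 2 by methyl in place of hydrogen on an aromatic carbon; cut one bond further out, the difference reads phenyl to 2-methylphenyl. Among the measured compounds shown here, no measured step concerns a methyl group or this ring, so the chloro step is the only guide to what one added atom on an aromatic carbon has done here, and that step was modest. The step from compound 2 to compound 3 is therefore expected to be a 1.0-fold lower number from compound 2 to compound 3 (0.01 log units; within the scatter), in no sure direction. Compound 3 is estimated at 12 nM in this assay, within 4 nM to 40 nM.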

Compound 3, dissociation constant: 33.8 nM
Beside the measured number, compound 3's estimate is 2.8-fold (0.45 log units) below it, and the stated range covers the measured number.
By their numbers in this assay, from the lowest: compound 1; then compound 2; then compound 3.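

In this assay, within the data shown here, the first change to this arylpiperazine phenyl, phenyl to 2-methylphenyl, gives a 2.8-fold higher number from compound 2 to compound 3 (0.44 log units; beyond the scatter), so this place, on an aromatic carbon ortho to a large group, does not tolerate a single added carbon without a shift in the number. The step is in the same direction as the chloro change elsewhere in the molecule, a 2.6-fold higher number from compound 1 to compound 2 (0.42 log units; beyond the scatter), and compound 3 now has the highest number of the three, though these two steps alone establish no general pattern. No evidence is available to explain why the methyl group raises the number here.

From the compounds shown here alone, it remains open whether a methoxy group or a fluorine atom at this place would shift the number in the same way. Also open, going by these compounds, is whether methyl at another place on this ring, or on the core of compound 1, would give a similar step.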